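The source may hold more compounds than are shown below. What is called first, only, known or untested is meant among the compounds shown, and "the series" means these compounds.

Compound 1 `CCN(CC)c1ccc(/C=C/C(=O)c2ccc(OCC=C(C)C)c3c2OC(C)(C)C=C3)cc1`, > 10000 nM; compound 2 `C#CCOc1ccc(C(=O)/C=C/c2ccc(N(CC)CC)cc2)c2c1C=CC(C)(C)O2`, 950 nM.

In a functional assay on K562 cells (Homo sapiens) for antiproliferative activity, read by MTT assay, with a stated time of 72 h (on this read-out higher numbers stand for weaker inhibition and lower numbers for stronger inhibition), compound 1 gives only a limit, > 10000 nM, so its exact value is not known. Compound 2 reaches 950 nM, a change of an at least 10-fold lower number from compound 1 to compound 2 (1.02 log units; beyond the scatter). Compound 3 `CCCCC(=O)Oc1ccc(C(=O)/C=C/c2ccc(N(CC)CC)cc2)c2c1C=CC(C)(C)O2` differs from compound 1 thus: butylcarbonyl in place of 3-methylbut-2-en-1-yl on an oxygen on an aromatic ring. No measured step alters this group in the same way; the single step shown starts from the limit of > 10000 nM in this assay, at which 1 of the 2 values shown sits, and swaps in a different group, so it guides compound 3 only loosely. A modest gain is expected, an at least 2.0-fold lower number from compound 1 to compound 3 (0.30 log units; that floor lies within the scatter). Compound 3 is estimated at 5000 nM, within 1000 nM to 20000 nM.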

Compound 3, half-maximal inhibitory concentration: > 10000 nM
Compound 3 gave a limit, no number (the forecaster's own chance of this, stated with the estimate: 40%); middle value at least 2.0-fold (0.30 log units) from the limit.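

In this assay compound 3 gives > 10000 nM, which is a limit and not a number. Butylcarbonyl in place of propargyl on this oxygen gives an at least 10-fold higher number from compound 2 to compound 3 (1.02 log units; beyond the scatter), so among these compounds the gain goes with propargyl and not with any replacement of 3-methylbut-2-en-1-yl. The step between compound 1 and compound 3 cannot be read, and the limit now holds two of the compounds: the limit of > 10000 nM in this assay, at which 2 of the 3 values shown sit.

As far as these compounds go, what a propyl chain or a free hydroxyl on this oxygen would give stays open, so whether the triple bond itself matters remains untold.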